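Notes: from 3-nitrophenyl to 4-nitrophenyl

The source may report more compounds than this note shows. Statements on the series, on what has been measured and on what is new or still open speak of the compounds shown alone.

In a physicochemical assay for lipophilicity (on this read-out higher numbers stand for higher lipophilicity and lower numbers for lower lipophilicity), compound 1 `O=C1/C(=C/c2ccccc2)CCC/C1=C\c1cccc([N+](=O)[O-])c1` gives 4.9, compound 2 `O=C1/C(=C/c2ccc(Cl)cc2)CCC/C1=C\c1cccc([N+](=O)[O-])c1` gives 5.58 and compound 3 `CN(C)c1ccc(/C=C2\CCC/C(=C\c3cccc([N+](=O)[O-])c3)C2=O)cc1` gives 5. The numbers show a number 0.10 log units higher from compound 1 to compound 3 (within the scatter) and a number 0.58 log units lower from compound 2 to compound 3 (beyond the scatter). Compound 3 therefore sits level with compound 1 and clearly under compound 2.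

The next structure is compound 4 `CN(C)c1ccc(/C=C2\CCC/C(=C\c3ccc([N+](=O)[O-])cc3)C2=O)cc1`, and the change is 4-nitrophenyl in place of 3-nitrophenyl on a double-bonded chain carbon bound to a double-bonded ring carbon. The two compounds have the same atoms, joined differently, and the dimethylamino group stays.

Within the data shown here, no measured step exchanges these two groups, so the evidence is indirect. The measured steps only swap hydrogen, chloro and dimethylamino on an aromatic carbon. The largest of these is a number 0.68 log units higher from compound 1 to compound 2 (beyond the scatter), and it involves a change of atoms, which the step to compound 4 does not.

No step beyond the scatter is expected in this assay, and neither direction is favoured. The expected step is no change at the digits printed from compound 3 to compound 4 (within the scatter). Compound 4 is estimated at 5, with an expected range of 4.6 to 5.4.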

Compound 4, partition coefficient: 5.03
The estimate for compound 4 lay 0.03 log units below the measured number, and the stated range covers the measured number.
By their numbers in this assay, from the lowest: compounds 1, 3 and 4 (each within the scatter of the next); then compound 2.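

In this assay, 4-nitrophenyl in place of 3-nitrophenyl on a double-bonded chain carbon bound to a double-bonded ring carbon gives a number 0.03 log units higher from compound 3 to compound 4 (within the scatter). Among these compounds, the earlier compounds all carry 3-nitrophenyl at this place, so this is the first reading of any change there, and with the dimethylamino group held constant the two nitrophenyl groups cannot be told apart on this read-out. Nothing at hand bears on why the two groups read alike.

From the compounds shown here alone, this pair has only the dimethylamino group on the other aromatic ring, so it remains open whether the same exchange reads alike with chloro or hydrogen in that place. Also open, going by these compounds, is how this place responds to a group other than nitro on the aromatic ring, such as a carboxylic acid or an amine.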